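The source may report more compounds than this note shows. Statements on the series, on what has been measured and on what is new or still open speak of the compounds shown alone.

In a functional assay on SGC-7901 cells (Homo sapiens) for cytotoxicity, read by MTT assay, with a stated time of 48 h (a lower number here means a stronger inhibitor, a higher number a weaker inhibitor), three compounds built on a shared core have been measured. Compound 1 `Cc1ncc([N+](=O)[O-])n1CCSc1nnc(-c2ccccc2)o1` gives 30100 nM, compound 2 `COc1ccc(-c2nnc(SCCn3c([N+](=O)[O-])cnc3C)o2)cc1` gives 10200 nM, and compound 3 `Cc1ncc([N+](=O)[O-])n1CCSc1nnc(-c2ccc(Cl)cc2)o1` gives 31900 nM. Compound 3 thus has a value within the scatter of that of compound 1, and the two stand apart from compound 2, as a 3.1-fold higher number from compound 2 to compound 3 (0.50 log units; beyond the scatter) shows.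

Compound 4 `Cc1ncc([N+](=O)[O-])n1CCSc1nnc(-c2cccnc2)o1` has not yet been measured. It has pyridin-3-yl in place of 4-chlorophenyl on an aromatic carbon. Going by the values given here, no measured step makes this exchange, so the evidence is indirect and comes from substituent changes on the aromatic group. Chloro in place of hydrogen gave a 1.1-fold higher number from compound 1 to compound 3 (0.03 log units; within the scatter), which lies within the scatter. Methoxy in place of hydrogen gave a 3.0-fold lower number from compound 1 to compound 2 (0.47 log units; beyond the scatter), a modest step beyond it. Compound 4 carries no methoxy, so the step to compound 2 offers it little guidance, and the values of compound 1 and compound 3 serve as the better reference. Among the compounds with values here, no step beyond the scatter is therefore expected in this assay, and the estimated change is a 1.1-fold lower number from compound 3 to compound 4 (0.03 log units; within the scatter), though the new ring hetero atom has no measured precedent here. For compound 4 the expected value is 30000 nM, with an estimated range from 11000 nM to 80000 nM.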

Compound 4, half-maximal inhibitory concentration: 31600 nM
The estimate for compound 4 lay 1.1-fold (0.02 log units) below the measured number; low and high end bracket the measured number.
By their numbers in this assay, from the lowest: compound 2; then compounds 1, 4 and 3 (each within the scatter of the next).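

In this assay, the position on the aromatic carbon of the five-membered ring tolerates a ring nitrogen as it tolerated chloro: pyridin-3-yl in place of 4-chlorophenyl gives no step beyond the scatter (a 1.0-fold lower number from compound 3 to compound 4 (0.00 log units; within the scatter)), nor does pyridin-3-yl in place of phenyl (a 1.0-fold higher number from compound 1 to compound 4 (0.02 log units; within the scatter)). The new group brings a hetero atom into the ring and a hydrogen-bond acceptor, and it has one heavy atom fewer than 4-chlorophenyl, yet among compounds 1, 3 and 4 none of these differences separates the numbers, while compound 2 with its 4-methoxyphenyl group alone stands apart, and compound 4 confirms this with a modest step (a 3.1-fold higher number from compound 2 to compound 4 (0.49 log units; beyond the scatter)). Nothing measured on these compounds offers an explanation for this picture.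

The compounds shown leave open whether the modest step of compound 2 is specific to methoxy or would also appear with an ethoxy group, a hydroxyl group or an amine on the phenyl ring. They also leave open how pyridin-2-yl or pyridin-4-yl would compare with pyridin-3-yl at this position, and whether a methoxy group on the pyridine ring would give a number nearer to that of compound 2.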